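Sulfonamide aryl swap: nitrophenyl to dichlorophenyl

The compounds below may be only part of what the source reports. "The series", "measured", "known", "first", "only" and "open" are said of these compounds alone.

Measured so far in a functional assay on MIA PaCa-2 cells (Homo sapiens) for inhibition, read by MTT assay, with a stated time of 72 h; on this read-out lower numbers stand for stronger inhibition of growth and higher numbers for weaker inhibition of growth:
compound 1, `O=S(=O)(NCCNCc1cccc2ccccc12)c1cc(C(F)(F)F)cc(C(F)(F)F)c1`, compound 1 gives 26000 nM
compound 2, `O=S(=O)(NCCCCNCc1ccc(Br)cc1)c1cc(C(F)(F)F)cc(C(F)(F)F)c1`, compound 2 gives 2100 nM
compound 3, `O=[N+]([O-])c1ccc(S(=O)(=O)NCCCCCCNCc2ccc(Br)cc2)cc1`, compound 3 gives 9800 nM

Compound 3 holds the second highest of the three numbers. Its nearest neighbour is compound 1, whose number lies higher by a margin beyond the scatter, while compound 2 sits furthest away, with a number lower than that of compound 3 by a gap that also lies beyond the scatter. No pair among these three differs in only one place, so no single step between measured compounds can be read off.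

Compound 4, `O=S(=O)(NCCCCCCNCc1ccc(Br)cc1)c1c(Cl)cccc1Cl`, keeps the hexyl linker and the 4-bromobenzyl end of compound 3 and changes only the aryl on the sulfonyl: 2,6-dichlorophenyl in place of 4-nitrophenyl on a sulfonyl sulfur. Since no comparable exchange has been measured here, the direction is open; the spread between compound 2 and compound 3 shows that the sulfonyl aryl and linker together can move the number by more than the scatter, but that pair differs in two places. A modest improvement is expected, not certainly beyond the scatter: the step of a 1.6-fold lower number from compound 3 to compound 4 (0.21 log units; within the scatter) is the estimate. Compound 4 is therefore expected to give 6000 nM, within a range from 2000 nM to 20000 nM.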

Compound 4, concentration for 50% growth inhibition: 14700 nM
For compound 4 the middle estimate is 2.5-fold (0.39 log units) below the measured one, and the stated range covers the measured number.
By their numbers in this assay, from the lowest: compound 2; then compounds 3, 4 and 1 (each within the scatter of the next, the first and the last beyond it).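

With the hexyl linker and the 4-bromobenzyl end held fixed, the exchange of 4-nitrophenyl for 2,6-dichlorophenyl on a sulfonyl sulfur gives, in this assay, a 1.5-fold higher number from compound 3 to compound 4 (0.18 log units; within the scatter). Among the compounds shown here, this is the first comparison that isolates the aryl on the sulfonyl, and it shows that two quite different groups, one carrying nitrogen and oxygen and the other chlorine, cannot be told apart on this read-out in this setting. Nothing available here accounts for that result.

The compounds shown leave open whether a phenyl bearing trifluoromethyl groups, or a phenyl bearing a carboxylic acid or an amine, on the same sulfonyl sulfur would also stay within the scatter of these two compounds with the hexyl linker and the 4-bromobenzyl end in place. For the compounds shown here, they also leave open what the chain contributes on its own, since no pair here differs only in the linker, so a butyl chain cannot be set against the hexyl chain with everything else held constant.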